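Series notes: amide aryl swap on the shared core

The source may report more compounds than this note shows. Statements on the series, on what has been measured and on what is new or still open speak of the compounds shown alone.

Measured so far:
- compound 1 `O=C(CSc1snnc1-c1ccc(Br)cc1Br)Nc1ccccc1[N+](=O)[O-]`: in an ADME assay on MT4 cells (Homo sapiens) for cytotoxicity, read by MTT assay, with a stated time of 5 days (on this read-out lower numbers stand for higher toxicity in this test and higher numbers for lower toxicity in this test), compound 1 gives > 235000 nM, a limit of the assay.
- compound 2 `Cc1ccc(NC(=O)CSc2snnc2-c2ccc(Br)cc2Br)c([N+](=O)[O-])c1`: in this assay compound 2 gives > 229000 nM, also a limit.
- compound 3 `O=C(CSc1snnc1-c1ccc(Br)cc1Br)Nc1ccccc1F`: in this assay compound 3 gives >= 27800 nM, again a limit.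

Compound 1 stands only at a limit in this assay, as do the two other values shown. Compound 4 `Cc1cccc(C)c1NC(=O)CSc1snnc1-c1ccc(Br)cc1Br` differs from compound 1 at the amide-type nitrogen: 2,6-dimethylphenyl in place of 2-nitrophenyl on an amide-type nitrogen. Two measured steps start from compound 1. The step that the two limits leave unreadable from compound 1 to compound 2 and the step that the two limits leave unreadable from compound 1 to compound 3 both run between limits, so neither gives a readable size; the evidence (the limit of > 229000 nM in this assay, at which 1 of the 3 values shown sits), the limit of > 235000 nM in this assay, at which 1 of the 3 values shown sits, and the limit of >= 27800 nM in this assay, at which 1 of the 3 values shown sits, consists of limits only. On this footing no step beyond the scatter can be expected in this assay in either direction, and the most likely outcome for compound 4 is again a limit. The estimate for compound 4 is 200000 nM, with a range from 30000 nM to 300000 nM, which corresponds to an expected step of an at least 1.1-fold lower number from compound 1 to compound 4 (0.07 log units; that floor lies within the scatter).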

Compound 4, half-maximal cytotoxic concentration: >= 198000 nM
Compound 4 gave a limit, no number (the forecaster's own chance of this, stated with the estimate: 70%); the middle value does not contradict the limit.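

The steps from compound 1 to compound 4 and from compound 3 to compound 4 both run between limits in this assay, so neither can be read. With all four values at limits, the compounds shown leave open whether any amide aryl swap on the shared core shifts the half-maximal cytotoxic concentration, and in which direction.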